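A few compounds are considered here, and "the series" means these few. Any claim that something is new, unique, unknown or untested is made for them only; others in the source may bear on it.

For the measured compounds named here, compound 2 `CNc1c(C)nc2c(OCc3ccccc3)cccn12` stands lowest of the two numbers so far: in a functional assay on the whole organism with Rattus norvegicus as the target, at a dose of 40 mg/kg by the intraperitoneal route (on this read-out higher numbers stand for more inhibition at the one dose given (going by the name of the read-out) and lower numbers for less inhibition), compound 2 gives 55%, whereas compound 1 `Cc1nc2c(OCc3ccccc3)cccn2c1N` gives 99%. Going by the values given here, the one step in hand, a number 44 percentage points lower from compound 1 to compound 2 (beyond the scatter), came from methyl in place of hydrogen on a nitrogen on an aromatic ring. Compound 3 `CCNc1c(C)nc2c(OCc3ccccc3)cccn12` carries the change (methyl in place of hydrogen on a saturated chain carbon bound to a nitrogen on an aromatic ring). Among the compounds with values here, only that earlier step bears on it, and loosely; it showed a large drop, so a further loss beyond the scatter is plausible but not of the same size. Compound 3 is expected to give 45%, within 20% to 70%. The expected step is a number 10 percentage points lower from compound 2 to compound 3 (within the scatter).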

Compound 3, a percentage reported as inhibition, in the whole organism at one dose (the size of the read-out at that dose, not a potency): 95%
Compound 3: the middle estimate sits 50 percentage points below what was measured; the whole stated range lies below it.
By their numbers in this assay, from the lowest: compound 2; then compounds 3 and 1 (each within the scatter of the next).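

In this assay substitution on this nitrogen does not by itself lower the read-out: methylamino to ethylamino gives a number 40 percentage points higher from compound 2 to compound 3 (beyond the scatter) and restores the level of the unsubstituted amine, as ethyl in place of hydrogen gives a number 4 percentage points lower from compound 1 to compound 3 (within the scatter) here. The loss seen with methyl therefore does not extend to ethyl, and among these three compounds only compound 2 stands apart. Nothing measured accounts for this difference between methyl and ethyl.

On these data alone, whether a propyl or longer chain on this nitrogen keeps the read-out remains open. So does the effect of a second ethyl group, as in diethylamino.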